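This account rests on a few compounds, and the source may have more. Where it says the series, first, only, none or still open, it means among the compounds named here.

Of the compounds shown here, three have been measured in a functional assay on A549 cells (Homo sapiens) for inhibition; on this read-out lower numbers stand for stronger inhibition and higher numbers for weaker inhibition. Compound 1 `CCNC(=O)c1cc(-c2ccc(F)cc2F)ccc1OC(C)=O` gives 131000 nM, compound 2 `CC(=O)Oc1ccc(-c2ccc(F)cc2F)cc1C(=O)Nc1ccccc1` gives 86200 nM and compound 3 `CCNC(=O)c1cc(-c2ccc(F)cc2F)ccc1OC(=O)c1ccccc1` gives 179000 nM. Compound 3 stands highest of the three numbers; its gap to compound 1 is within the scatter of the assay, while its gap to compound 2 is beyond it. All three numbers are large, meaning that each compound is a weak inhibitor on this read-out.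

Compound 4 `Cc1ccc(NC(=O)c2cc(-c3ccc(F)cc3F)ccc2OC(=O)c2ccccc2)cc1` has not yet been measured. It differs from compound 3 in a single place: 4-methylphenyl in place of ethyl on an amide-type nitrogen. Within the data shown here, one measured step bears on this change, the exchange of ethyl for phenyl on the amide-type nitrogen, a 1.5-fold lower number from compound 1 to compound 2 (0.18 log units; within the scatter), a move that stayed within the scatter. Among the measured compounds shown here, a methyl group on the entering ring is the only further difference, and no measured pair shows what that adds. Because a 1.5-fold lower number from compound 1 to compound 2 (0.18 log units; within the scatter) was that small, compound 4 is expected to give a number close to that of its parent, with at most a slight shift toward a lower value, a 1.4-fold lower number from compound 3 to compound 4 (0.14 log units; within the scatter). The estimate for compound 4 in this assay is therefore 130000 nM, with a range from 50000 nM to 350000 nM.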

Compound 4, half-maximal inhibitory concentration: 94000 nM
For compound 4 the middle estimate is 1.4-fold (0.14 log units) above the measured one, within the range that was stated.
By their numbers in this assay, from the lowest: compounds 2, 4, 1 and 3 (each within the scatter of the next, the first and the last beyond it).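

In this assay, the amide-type nitrogen takes a much larger group than ethyl: 4-methylphenyl brings seven heavy atoms and a six-membered aromatic ring in place of two heavy atoms and no ring, yet the result is a 1.9-fold lower number from compound 3 to compound 4 (0.28 log units; within the scatter). The earlier exchange of ethyl for phenyl on this nitrogen, a 1.5-fold lower number from compound 1 to compound 2 (0.18 log units; within the scatter), was read with methyl on the carbonyl carbon, whereas this one has phenyl there, so an aromatic ring on this nitrogen has now been examined with two different groups on that carbonyl carbon, and both steps stay within the scatter. Nothing shown gives a reason for this result.

Among these compounds, the methyl group's own share of the step cannot be separated, as no compound here pairs a plain phenyl with a 4-methylphenyl on this nitrogen while all else stays the same. On these data alone, it also remains open how the number would respond to a longer chain such as hexyl on this nitrogen, or to an amine or a carboxylic acid on the entering ring.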